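The source may hold more compounds than are shown below. What is called first, only, known or untested is meant among the compounds shown, and "the series" means these compounds.

Two close relatives have been measured in a functional assay on SK-MEL-2 cells (Homo sapiens) for cytotoxicity, read by sulforhodamine B assay, with a stated time of 48 h (a lower number here means a stronger inhibitor of growth, a higher number a weaker inhibitor of growth), so far. Compound 1 `ClCc1ccc(Cn2cnc3c(Cl)ncnc32)cc1` gives 4360 nM there, the lower of the two numbers. Compound 2 `Nc1nc(Cl)c2ncn(Cc3ccccc3CCl)c2n1` gives 18600 nM in this assay, a weaker inhibitor of growth than compound 1.

Compound 3 `ClCc1ccc(Cn2cnc3c(Cl)nc(Cl)nc32)cc1` differs from compound 1 in one place: chloro in place of hydrogen on an aromatic carbon. For the measured compounds named here, no measured pair shows what this change does. A small step toward a lower number, not clearly beyond the scatter, is expected from compound 1 to compound 3, that is a 1.5-fold lower number from compound 1 to compound 3 (0.16 log units; within the scatter). Compound 3 is therefore estimated at 3000 nM in this assay, within a range from 1000 nM to 10000 nM.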

Compound 3, concentration for 50% growth inhibition: 20000 nM
For compound 3 the middle estimate is 6.7-fold (0.82 log units) below the measured one; measured number outside the range, above it.
By their numbers in this assay, from the lowest: compound 1; then compounds 2 and 3 (each within the scatter of the next).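

Chloro on the aromatic carbon between two ring nitrogen atoms gives a 4.6-fold higher number from compound 1 to compound 3 (0.66 log units; beyond the scatter) in this assay and so shows that this position is sensitive: one added heavy atom is enough to weaken growth inhibition beyond the scatter. No measurement at hand gives a reason for this step. On these data alone, whether the loss is specific to chloro stays open. A fluoro, a methoxy group or an amine on this same carbon could show whether other groups are treated the same way.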